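Another group on the ring nitrogen, same chlorophenyl ketone core

The compounds below may be only part of what the source reports. "The series", "measured", "known", "first", "only" and "open" are said of these compounds alone.

Measured so far:
compound 1, `Nc1scc(CN2CCN(c3ccccc3C(F)(F)F)CC2)c1C(=O)c1ccc(Cl)cc1`, 0%
compound 2, `Nc1scc(CN2CCN(C3CCCC3)CC2)c1C(=O)c1ccc(Cl)cc1`, 3%
compound 3, `Nc1scc(CN2CCN(c3cccc(F)c3F)CC2)c1C(=O)c1ccc(Cl)cc1`, 0%

All three compounds were tested in an assay on CHO cells for displacement of a labelled ligand from adenosine receptor A3 (Homo sapiens), read by scintillation counting, with a stated time of 120 min, tested at 10 uM; a higher number here means more inhibition at the concentration tested (going by the name of the read-out), a lower number less inhibition. In this assay compound 1 gives 0% and compound 2 gives 3%, while compound 3 gives 0%. Compound 3 therefore stands level with compound 1 at the digits printed, and the two together are the lowest of the three numbers; its nearest neighbour is compound 1, with no change at the digits printed from compound 1 to compound 3 (within the scatter), and its furthest is compound 2, with a number 3 percentage points lower from compound 2 to compound 3 (within the scatter).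

Compound 4, `Nc1scc(CN2CCN(c3cccc(Cl)c3)CC2)c1C(=O)c1ccc(Cl)cc1`, has not yet been measured. It differs from compound 3 in one place: 3-chlorophenyl in place of 2,3-difluorophenyl on an amine nitrogen in a ring.

The three steps already seen all exchange the group on this same amine nitrogen in a ring: a number 3 percentage points higher from compound 1 to compound 2 (within the scatter), no change at the digits printed from compound 1 to compound 3 (within the scatter) and a number 3 percentage points lower from compound 2 to compound 3 (within the scatter). None of them moved the number beyond the scatter, whether the group was cyclopentyl or one of two substituted phenyls. For compound 4 the step is therefore expected to be a number 2 percentage points higher from compound 3 to compound 4 (within the scatter), that is no change beyond the scatter. The estimate for compound 4 in this assay is 2%, with a range from 0% to 14%.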

Compound 4, a percentage reported as inhibition, at one concentration (the size of the read-out at that concentration, not a potency): 1%
The estimate for compound 4 lay 1 percentage points above the measured number, within the range that was stated.
By their numbers in this assay, from the lowest: compounds 1, 3, 4 and 2 (each within the scatter of the next).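

Placing 3-chlorophenyl on the amine nitrogen in a ring gives, in this assay, a number 1 percentage points higher from compound 3 to compound 4 (within the scatter), and the comparisons with the other two groups give a number 2 percentage points lower from compound 2 to compound 4 (within the scatter) and a number 1 percentage points higher from compound 1 to compound 4 (within the scatter). The earlier compounds shown here held this position only with cyclopentyl, 2-(trifluoromethyl)phenyl and 2,3-difluorophenyl; a phenyl carrying a single chlorine now joins them, and all four groups remain within the scatter of one another on the shared core. Nothing measured here offers an explanation for this lack of separation among the four groups.

The compounds shown leave open whether any group on this nitrogen can move the reading beyond the scatter, for example a longer alkyl chain, a benzyl group, or a phenyl carrying a carboxylic acid or an amine. With the core held constant in all four compounds, they also cannot tell whether a different group on the ketone, such as an unsubstituted phenyl or a methoxyphenyl, would change how the nitrogen substituent reads in this assay.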